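This account rests on a few compounds, and the source may have more. Where it says the series, first, only, none or still open, it means among the compounds named here.

Measured compounds:
compound 1, `C=CCONC(=O)CN1C(=O)S/C(=C\c2ccc(C(=O)N[C@@H](CC(C)C)C(=O)OC)cc2)C1=O`: in a functional assay on RAW264.7 cells (Mus musculus) for inhibition, read by microscopy and resazurin assay, with a stated time of 72 h (a lower number here means a stronger inhibitor, a higher number a weaker inhibitor), compound 1 gives > 128000 nM, a limit of the assay.
compound 2, `COC(=O)[C@H](CC(C)C)NC(=O)c1ccc(/C=C2\SC(=O)N(CC(=O)NOCc3ccccc3)C2=O)cc1`: in this assay compound 2 gives > 128000 nM, again a limit.
compound 3, `C=CCONC(=O)Cn1cc(C(=O)NCC(=O)N[C@H](C(=O)O)C(C)C)c2ccccc21`: in this assay compound 3 gives > 128000 nM, also a limit.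

None of the three values is a number; (the limit of > 128000 nM in this assay, at which 3 of the 3 values shown sit). Compound 1 and compound 2 share a core, and compound 2 differs by phenyl in place of vinyl on a saturated chain carbon bound to an oxygen on an unsaturated carbon. The step that the two limits leave unreadable from compound 1 to compound 2 is unreadable, as both ends are limits. Compound 3 rests on another core; the difference between the two cores is not broken down here.

Compound 4, `CC(C)[C@H](NC(=O)CNC(=O)c1cn(CC(=O)NOCc2ccccc2)c2ccccc12)C(=O)O`, is still to be measured in this assay. It stands to compound 3 as compound 2 stands to compound 1, carrying (phenyl in place of vinyl on a saturated chain carbon bound to an oxygen on an unsaturated carbon), the same change at the same place. The earlier step that the two limits leave unreadable from compound 1 to compound 2 offers no size to lean on. Within the data shown here, what remains is that every value so far sits at the limit, (the limit of > 128000 nM in this assay, at which 3 of the 3 values shown sit). Compound 4 is therefore expected to stay at the limit as well, with an estimated step of a number no higher from compound 3 to compound 4 (the limit leaves the size open). The estimate for compound 4 is 128000 nM, expected to fall between 60000 nM and 250000 nM.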

Compound 4, half-maximal inhibitory concentration: > 128000 nM
Compound 4 ended at the assay's limit; the forecaster's own chance of this, stated with the estimate: 85%; the middle value lies on the limit itself.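

In this assay compound 4 gives > 128000 nM, a limit and not a number. The step from compound 3 to compound 4 cannot be read, because both ends are limits: the limit of > 128000 nM in this assay, at which 4 of the 4 values shown sit.

The compounds shown leave open whether allyloxy to benzyloxy changes inhibition on either core, since none of them gives a numerical value.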